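Swapping Bromo for Hydroxy on a Second Core

The source may report more compounds than this note shows. Statements on the series, on what has been measured and on what is new or still open speak of the compounds shown alone.

Compound 1 `OCC#CCSc1cnc2ccccc2c1SCC#CCBr` and compound 2 `OCC#CCSc1cnc2ccccc2c1SCC#CCO` share one core and differ in a single place: hydroxy in place of bromo on a saturated chain carbon bound to a triple-bonded carbon. In a functional assay on CCRF-CEM cells (Homo sapiens) for cytotoxicity, read by sulforhodamine B assay, with a stated time of 72 h (a higher number here means a weaker inhibitor, a lower number a stronger inhibitor), compound 1 gives 0.6 ug/mL, and in this assay compound 2 gives 2.6 ug/mL. That change made a 4.3-fold higher number from compound 1 to compound 2 (0.64 log units; beyond the scatter). Compound 3 `C#CCSc1cnc2ccccc2c1[Se]CC#CCBr` is built on another core; how its core differs from that of compound 1 is not broken down here. In this assay compound 3 gives 0.3 ug/mL. Compound 4 `C#CCSc1cnc2ccccc2c1[Se]CC#CCO` is the partner of compound 3 carrying the same change: hydroxy in place of bromo on a saturated chain carbon bound to a triple-bonded carbon. A step of similar size is expected for compound 4 because the same change earlier gave a 4.3-fold higher number from compound 1 to compound 2 (0.64 log units; beyond the scatter). The expected step is a 4.3-fold higher number from compound 3 to compound 4 (0.64 log units; beyond the scatter). Compound 4 is therefore estimated at 1.3 ug/mL, most likely falling between 0.5 ug/mL and 3.5 ug/mL.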

Compound 4, concentration for 50% inhibition: 3.2 ug/mL
Compound 4: the middle estimate sits 2.5-fold (0.39 log units) below what was measured; measured number inside the range.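

On the second core, hydroxy in place of bromo gives an 11-fold higher number from compound 3 to compound 4 (1.03 log units; beyond the scatter) in this assay, the same direction as on the first core. Set side by side, the two steps do not differ by more than the usual scatter allows: the same change on two cores in this assay, a 4.3-fold higher number (0.64 log units; beyond the scatter) from compound 1 to compound 2 and an 11-fold higher number (1.03 log units; beyond the scatter) from compound 3 to compound 4, 2.5-fold (0.39 log units) apart, within the scatter of two such steps This shows that the change carried over from one core to the other in these two pairs, but two pairs do not make a rule for the whole series, and the numbers do not explain why the change has this effect.

Only bromo and hydroxy appear at this place in the compounds shown. On these data alone, what a chloro group, an amine or a longer chain would do there remains open, as does the size of this step on any third core.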